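Methoxy for Methyl: Expecting the Step to Compound 3

The source may hold more compounds than are shown below. What is called first, only, known or untested is meant among the compounds shown, and "the series" means these compounds.

Measured compounds:
compound 1, `Cc1cccc(Nc2nccc(-c3ccc(Br)cc3)n2)c1`, > 1000 nM
compound 2, `O=[N+]([O-])c1ccc(Nc2nccc(-c3ccc(Cl)c(Cl)c3)n2)cc1`, 573 nM

Of the compounds shown here, two sharing a common core have been tested in an assay on isolated protein for inhibition of phosphatidylinositol 4,5-bisphosphate 3-kinase catalytic subunit beta isoform (Homo sapiens); on this read-out higher numbers stand for weaker inhibition and lower numbers for stronger inhibition. Compound 1 reaches only the limit of the method, so its result is not a number but a bound: in this assay compound 1 gives > 1000 nM. Among the measured compounds shown here, compound 2 is the one member of this pair with a true value; in this assay compound 2 gives 573 nM. The two structures differ in more than one place, so the gap between them cannot be split into single steps; all that can be said is that compound 1 sits at the limit, as stated by the limit of > 1000 nM in this assay, at which 1 of the 2 values shown sits, while compound 2 sits below it.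

Compound 3, `COc1cccc(Nc2nccc(-c3ccc(Br)cc3)n2)c1`, is not yet measured. It differs from compound 1 by methoxy in place of methyl on an aromatic carbon. For the measured compounds named here, because compound 1 itself shows only > 1000 nM, no measured step anchors this change, and the expected step from compound 1 to compound 3 is a step that the limit leaves unreadable from compound 1 to compound 3, within the usual scatter. Compound 3 is therefore expected to give about 1500 nM, between 400 nM and 6000 nM, with a fair chance that this assay again reports only a limit.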

Compound 3, half-maximal inhibitory concentration: 977 nM
Compound 3: middle estimate off by 1.5-fold (0.19 log units), on the high side, and the stated range covers the measured number.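

Compound 3 gives 977 nM in this assay, so this position, on an aromatic carbon meta to a large group, now carries a true number on the core of compound 1. Methoxy in place of methyl there amounts to an at least 1.0-fold lower number from compound 1 to compound 3 (0.01 log units; that floor lies within the scatter) and so shows only that the change keeps the compound within the range that the method can read, with no shift beyond the scatter established. How large the step really is cannot be read, because the result for compound 1 is a limit of the assay and not a number: the limit of > 1000 nM in this assay, at which 1 of the 3 values shown sits.

The compounds shown leave open whether an amine, a hydroxyl or a longer chain such as ethoxy at this same position would give a number that stands clear of the scatter from compound 3. Nor do they tell whether methoxy in place of methyl would give a readable step when the starting compound has a true number rather than a limit.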